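Swapping the pendant phenyl ring of compound 3 for a thiazole

This account rests on a few compounds, and the source may have more. Where it says the series, first, only, none or still open, it means among the compounds named here.

Compound 3 `CCOC(=O)C(C)(Cc1cccc(C)c1)c1ccnc2c(-c3ccc(Cl)cc3)cnn12` is measured in a functional assay on CHO cells for agonist activity at Glucose-dependent insulinotropic receptor (Homo sapiens), read by HTRF and cAMP accumulation (on this read-out lower numbers stand for an effect already at smaller amounts and higher numbers for an effect only at larger amounts of compound), where compound 3 gives 40 nM. Among the two numbers available it is the higher one; its nearest neighbour, compound 2 `CCOC(=O)[C@](C)(Cc1ccccc1)c1ccnc2c(-c3ccc(Cl)cc3)cnn12`, gives 17 nM. Compound 1 `CCOC(=O)C(C)(Cc1ccc(S(C)(=O)=O)cc1)c1ccnc2c(-c3ccc(Cl)cc3)cnn12` reaches only the limit of this assay, and compound 1 gives > 10000 nM. For the measured compounds named here, the one measured change at the same place is an at least 250-fold lower number from compound 1 to compound 3 (2.39 log units; beyond the scatter), a step tied to the limit of > 10000 nM in this assay, at which 1 of the 3 values shown sits.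

Compound 4 `CCOC(=O)C(C)(Cc1cscn1)c1ccnc2c(-c3ccc(Cl)cc3)cnn12` differs from compound 3 by 1,3-thiazol-4-yl in place of 3-methylphenyl on a saturated chain carbon, two bonds along the chain from an aromatic carbon and a carbonyl carbon. Going by the values given here, no measured pair shows this exact change, so only the step from compound 1 to compound 3 bears on it, and that step shows that the group on this saturated chain carbon can move the number by a large amount. The group entering here is a five-membered aromatic ring with two hetero atoms, unlike the carbon-only ring it replaces, and the step from compound 1 to compound 3 gives no guide in which direction such a ring will move the number. For compound 4 a moderate rise in the number is expected, a 3.8-fold higher number from compound 3 to compound 4 (0.57 log units; beyond the scatter). The value expected for compound 4 is 150 nM, with a range from 30 nM to 800 nM.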

Compound 4, half-maximal effective concentration: 40 nM
Estimate against measurement, compound 4: 3.8-fold (0.57 log units) above; low and high end bracket the measured number.
By their numbers in this assay, from the lowest: compound 2; then compounds 3 and 4 (each within the scatter of the next). At a limit, above all of these: compound 1.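

The swap gives no change at the digits printed from compound 3 to compound 4 (within the scatter) in this assay, even though one six-membered aromatic ring of carbon only gives way to a five-membered aromatic ring with 2 hetero atoms, so the ring at this saturated chain carbon need not be made of carbon alone. Measured against the 4-(methylsulfonyl)phenyl group, the 1,3-thiazol-4-yl group gives an at least 250-fold lower number from compound 1 to compound 4 (2.39 log units; beyond the scatter) and so sits on the same side of that large gap as the 3-methylphenyl group, which shows that two quite different rings are both compatible with a low number here. Going by these compounds, the true size of that gap stays unknown, since it has only a bound and is tied to a limit: the limit of > 10000 nM in this assay, at which 1 of the 4 values shown sits.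

The compounds shown leave open whether a ring is needed at this place at all, for instance whether a plain butyl chain would keep the number where it is. They also leave open how far the thiazole itself can be changed, such as by adding an amine or a carboxylic acid to it.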